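Ortho cyano to ethyl on the aryl ether of the piperidine series

The compounds below may be only part of what the source reports. "The series", "measured", "known", "first", "only" and "open" are said of these compounds alone.

Two compounds of this series have numbers in an assay on microsomes from liver for inhibition of acyl-CoA desaturase 1 (Rattus norvegicus); a higher number here means a weaker inhibitor, a lower number a stronger inhibitor. Compound 1 `Cc1cccc(OC2CCN(c3ccc(-n4ccnc4)nn3)CC2)c1` gives 251 nM and compound 2 `N#Cc1ccccc1OC1CCN(c2ccc(-n3ccnc3)nn2)CC1` gives 236 nM. Among the compounds with values here, the one step, a 1.1-fold lower number from compound 1 to compound 2 (0.03 log units; within the scatter), shows that swapping the aryl group on the ether oxygen left the number where it was. Compound 2 stands lowest of the two, with compound 1 within the scatter of it. Compound 3 `CCc1ccccc1OC1CCN(c2ccc(-n3ccnc3)nn2)CC1` carries ethyl in place of cyano on an aromatic carbon. Within the data shown here, no measured step bears directly on this change, and the single step seen was flat; no step beyond the scatter is expected in this assay, so compound 3 is estimated at 250 nM (range 100 nM to 650 nM), meaning an expected step of a 1.1-fold higher number from compound 2 to compound 3 (0.03 log units; within the scatter).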

Compound 3, half-maximal inhibitory concentration: 4 nM
For compound 3 the middle estimate is 63-fold (1.80 log units) above the measured one, and the stated range ends above it.
By their numbers in this assay, from the lowest: compound 3; then compounds 2 and 1 (each within the scatter of the next).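

In this assay the substituent on the aryl ether proves far from flat: ethyl in place of cyano gives a 59-fold lower number from compound 2 to compound 3 (1.77 log units; beyond the scatter) and 2-ethylphenyl in place of 3-methylphenyl gives a 63-fold lower number from compound 1 to compound 3 (1.80 log units; beyond the scatter) on the same series. This aromatic carbon therefore responds strongly to the group it carries, which the step between the two earlier compounds did not reveal. No measurement shown accounts for this gain.

Still open, from the compounds shown here alone, is whether the gain is specific to ethyl. Methyl, propyl, methoxy or an amine on the same aromatic carbon would show how narrow the preference is.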